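Sulfamoyl in Place of Phenylsulfanyl on a Shared Core

The compounds below may be only part of what the source reports. "The series", "measured", "known", "first", "only" and "open" are said of these compounds alone.

Compound 1 `CC(O)(C(=O)Nc1ccc(Sc2ccccc2)cc1)C(F)(F)F`: > 30000 nM
Compound 2 `CC(O)(C(=O)Nc1ccc(/C(=N\O)c2ccccc2)cc1)C(F)(F)F`: > 30000 nM
Compound 3 `CC(O)(C(=O)Nc1ccc([C@@H](O)c2ccccc2)cc1)C(F)(F)F`: > 30000 nM

In an assay on a protein complex (Cavia porcellus) with sulfonylurea receptors; K-ATP channels (Homo sapiens) as the target (on this read-out higher numbers stand for weaker inhibition and lower numbers for stronger inhibition), compound 1 gives > 30000 nM, which is a limit of the assay and not a number. Compound 2 likewise gives only a limit in this assay, > 30000 nM. Compound 3 gives > 30000 nM, again a limit. Every value shown therefore sits at the limit of > 30000 nM in this assay, at which 3 of the 3 values shown sit, and compound 1 stands nowhere in particular among them: none of the three can be placed above or below another. Within the data shown here, the one step between compounds that differ in a single place, a step that the two limits leave unreadable from compound 1 to compound 3, is accordingly unreadable, since both ends are limits.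

Compound 4 `CC(O)(C(=O)Nc1ccc(S(N)(=O)=O)cc1)C(F)(F)F` differs from compound 1 by sulfamoyl in place of phenylsulfanyl on an aromatic carbon. Among the measured compounds shown here, no measured step touches this change, and the only step available gives no size at all. The expected step from compound 1 to compound 4 is thus a number no higher from compound 1 to compound 4 (the limit leaves the size open), resting on nothing firmer than the limits shown. Compound 4 is expected to give about 30000 nM, within a range from 8000 nM to 120000 nM, with a substantial chance that this assay again reports only a limit.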

Compound 4, half-maximal inhibitory concentration: 12800 nM
Compound 4: middle estimate off by 2.3-fold (0.37 log units), on the high side, within the range that was stated.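

In this assay compound 4 is the only compound shown that gives a number, 12800 nM, and not a limit, so this position, para to a large group, can carry a group that brings the read-out within measurable range. Sulfamoyl in place of phenylsulfanyl gives an at least 2.3-fold lower number from compound 1 to compound 4 (0.36 log units; beyond the scatter), and sulfamoyl in place of hydroxy(phenyl)methyl gives an at least 2.3-fold lower number from compound 3 to compound 4 (0.36 log units; beyond the scatter). The entering group has no ring, whereas both leaving groups carry a six-membered aromatic ring of carbon only, so among these compounds a measurable value at this position does not depend on that ring.

Whether it is the sulfamoyl group as such that matters stays open, since the compounds shown do not tell how a methylsulfonyl group, a carboxylic acid or a simple amine would read at the same place. How large the two steps truly are also stays open, as each gives only a lowest size and the other values shown offer no number to measure from: the limit of > 30000 nM in this assay, at which 3 of the 4 values shown sit.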